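The source may hold more compounds than are shown below. What is called first, only, known or untested is meant among the compounds shown, and "the series" means these compounds.

Measured in a toxicity assay on HUVEC cells (Homo sapiens) for inhibition; a higher number here means a weaker inhibitor of growth, a lower number a stronger inhibitor of growth:
Compound 1 `O=C(Oc1ccccc1)c1ccsc1NC(=O)[C@@H]1CCCN1`: > 250 ug/mL, a limit
Compound 2 `O=C(OCC(Cl)(Cl)Cl)c1ccsc1NC(=O)[C@@H]1CCCN1`: > 250 ug/mL, a limit

Compound 2 stands at a limit in this assay, > 250 ug/mL, and not at a number. The same limit holds for both measured compounds: the limit of > 250 ug/mL in this assay, at which 2 of the 2 values shown sit. Going by the values given here, the only measured step is a step that the two limits leave unreadable from compound 1 to compound 2.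

Compound 3 `O=C1CC[C@@H](COC(=O)c2ccsc2NC(=O)[C@@H]2CCCN2)N1` carries 5-oxopyrrolidin-2-yl in place of trichloromethyl on a saturated chain carbon bound to an oxygen next to a carbonyl group.

Among the compounds with values here, no measured step gives this change a size, so no step beyond the scatter is expected in this assay. The expected step is a step that the limit leaves unreadable from compound 2 to compound 3. For compound 3 the estimate is 350 ug/mL, with an expected range from 150 ug/mL to 1000 ug/mL.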

Compound 3, concentration for 50% growth inhibition: 88.6 ug/mL
Compound 3: middle estimate off by 4.0-fold (0.60 log units), on the high side, outside the stated range (below it).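

In this assay, this position turns out to matter: 5-oxopyrrolidin-2-yl in place of trichloromethyl gives an at least 2.8-fold lower number from compound 2 to compound 3 (0.45 log units; beyond the scatter), and the wider change from phenyl gives an at least 2.8-fold lower number from compound 1 to compound 3 (0.45 log units; beyond the scatter). A lower number here means stronger inhibition of growth, so the group at this place can make a compound more toxic to these cells. Both steps give only a minimum size because the earlier compounds do not give a number: the limit of > 250 ug/mL in this assay, at which 2 of the 3 values shown sit.

From the compounds shown here alone, whether the ring of 5-oxopyrrolidin-2-yl is needed stays open. So does whether a simple amine or a carboxylic acid on the same saturated chain carbon would also lower the number.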